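Removing One Trifluoromethyl from a Bis-Trifluoromethyl Anilide

The source may hold more compounds than are shown below. What is called first, only, known or untested is meant among the compounds shown, and "the series" means these compounds.

Measured so far:
compound 1, `O=C(Nc1cc(C(F)(F)F)ccc1C(F)(F)F)c1cc(Cl)ccc1O`, 20000 nM
compound 2, `O=C(Nc1ccc(C(F)(F)F)c(C(F)(F)F)c1)c1cc(Cl)ccc1O`, 13000 nM
compound 3, `O=C(Nc1ccc(C(F)(F)F)cc1)c1cc(Cl)ccc1O`, 16000 nM

In an assay for inhibition of transmembrane protease serine 4 (Homo sapiens), read by fluorescence (on this read-out higher numbers stand for weaker inhibition and lower numbers for stronger inhibition), compound 2 gives the lowest of the three numbers, yet its gaps to compound 3 and to compound 1 both lie within the scatter, so no order among them can be claimed. Compound 4, `O=C(Nc1cccc(C(F)(F)F)c1)c1cc(Cl)ccc1O`, differs from compound 2 by hydrogen in place of trifluoromethyl on an aromatic carbon. For the measured compounds named here, the one measured step of the same kind, a 1.2-fold higher number from compound 2 to compound 3 (0.09 log units; within the scatter), stayed within the scatter. On that basis compound 4 is expected to show no step beyond the scatter, with a 1.2-fold higher number from compound 2 to compound 4 (0.06 log units; within the scatter). The estimate for compound 4 in this assay is 15000 nM, with a range from 6000 nM to 40000 nM.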

Compound 4, half-maximal inhibitory concentration: 13000 nM
Estimate against measurement, compound 4: 1.2-fold (0.06 log units) above, and the stated range covers the measured number.
By their numbers in this assay, from the lowest: compounds 2, 4, 3 and 1 (each within the scatter of the next).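

In this assay, at this place, ortho to a trifluoromethyl group and para to a large group, hydrogen in place of trifluoromethyl gives no change at the digits printed from compound 2 to compound 4 (within the scatter). The same exchange, starting from a different arrangement of the two trifluoromethyl groups, gives a 1.5-fold lower number from compound 1 to compound 4 (0.19 log units; within the scatter). Read together with the earlier step, the change stays within the scatter on both cores, and the two steps do not differ beyond it: the same change on two cores in this assay, a 1.2-fold higher number (0.09 log units; within the scatter) from compound 2 to compound 3 and a 1.5-fold lower number (0.19 log units; within the scatter) from compound 1 to compound 4, 1.9-fold (0.28 log units) apart, within the scatter of two such steps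

The compounds shown leave open whether a nitrile, an amine or a carboxylic acid at this place would move the number beyond the scatter. They also give no order among the four anilides.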